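The source may hold more compounds than are shown below. What is called first, only, known or untested is meant among the compounds shown, and "the series" means these compounds.

Working notes on the series. Compound 1 `CNC(=O)CCCCCCCn1nc(-c2ccc3oc(N)nc3c2)c2c(N)ncnc21` is measured in a functional assay on HepG2 cells (Homo sapiens) for inhibition, read by MTT assay, with a stated time of 72 h (on this read-out higher numbers stand for weaker inhibition and lower numbers for stronger inhibition), where compound 1 gives 3640 nM. Compound 2 `Nc1ncnc2c1c(-c1cnc3[nH]ccc3c1)nn2CCCCCCCCC(=O)NO` in this assay gives 3050 nM; compound 1 sits at one end of the two numbers, with compound 2 within the scatter of it. Compound 3 `Nc1nc2cc(-c3nn(CCCCC(=O)NO)c4ncnc(N)c34)ccc2o1` is not yet measured; it differs from compound 1 in one place: hydroxycarbamoyl in place of 3-(methylcarbamoyl)propyl on a saturated chain carbon, four bonds along the chain from an aromatic nitrogen. Going by the values given here, no measured pair shows this change, so the expected step from compound 1 to compound 3 in this assay, a 1.1-fold higher number from compound 1 to compound 3 (0.04 log units; within the scatter), is small, toward a higher number, and scarcely beyond the scatter. Compound 3 is expected to give 4000 nM in this assay, within 1500 nM to 11000 nM.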

Compound 3, half-maximal inhibitory concentration: 2100 nM
For compound 3 the middle estimate is 1.9-fold (0.28 log units) above the measured one, within the range that was stated.
By their numbers in this assay, from the lowest: compounds 3, 2 and 1 (each within the scatter of the next).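

In this assay, going by these compounds alone, the first measured pair for this change, hydroxycarbamoyl in place of 3-(methylcarbamoyl)propyl on a saturated chain carbon, four bonds along the chain from an aromatic nitrogen, gives a 1.7-fold lower number from compound 1 to compound 3 (0.24 log units; within the scatter). At this position, the read-out therefore does not separate the two end groups. No evidence bearing on this result is available. Open, on these data alone, is whether a carboxylic acid or an amine in the same place would give a step beyond the scatter.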